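This account rests on a few compounds, and the source may have more. Where it says the series, first, only, none or still open, it means among the compounds named here.

In a functional assay on KOPN-8 cells (Homo sapiens) for antiproliferative activity, with a stated time of 72 h (a lower number here means that less compound is needed, a higher number that more compound is needed for the effect), compound 1 `COc1ccc(-c2cc(=O)c3c(OC)cc(OC)cc3n2C)cc1` gives 30000 nM, while compound 2 `COc1ccc(-c2c(Br)c(=O)c3c(OC)cc(OC)cc3n2S(=O)(=O)c2ccc(OC)cc2)cc1` gives 2580 nM. Compound 3 `COC(=O)c1cc(=O)c2c(OC)cc(OC)cc2[nH]1` reads > 34400 nM, which is a limit of the assay and not a number. Compound 3 thus stands at the limit of > 34400 nM in this assay, at which 1 of the 3 values shown sits.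

Compound 4 `COC(=O)c1cc(=O)c2c(OC)cc(OC)cc2n1C` differs from compound 3 in one place, with methyl in place of hydrogen on an aromatic nitrogen. The methyl sits ortho to a methoxycarbonyl group, which compound 4 retains.

No measured pair among these compounds isolates this change, so the expectation rests on thin ground. Compound 1 also bears a methyl on the aromatic nitrogen, and it gives 30000 nM. That value offers no reason to expect a large gain in this assay from the added methyl, so at most a modest move towards lower numbers is expected, and possibly none beyond the usual scatter. The expected change is an at least 1.1-fold lower number from compound 3 to compound 4 (0.05 log units; that floor lies within the scatter), and the assay may again report only a limit. For compound 4 the estimated value is 30000 nM, with an expected range of 10000 nM to 60000 nM.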

Compound 4, half-maximal effective concentration: > 19000 nM
Compound 4 gave a limit, no number; the forecaster's own chance of this, stated with the estimate: 55%; the middle value does not contradict the limit.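

In this assay compound 4 reads > 19000 nM, which is a limit of the assay and not a number. Neither the step from compound 3 to compound 4 nor the step from compound 1 to compound 4 can be read. The compounds shown leave open whether methyl in place of hydrogen on an aromatic nitrogen changes the value at all.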